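Piperidine to Morpholine on the Thiocarbonyl: Expected Potency

A few compounds are considered here, and "the series" means these few. Any claim that something is new, unique, unknown or untested is made for them only; others in the source may bear on it.

Measured in a functional assay on MCF7 cells (Homo sapiens) for antiproliferative activity, read by MTT assay, with a stated time of 72 h (a higher number here means a weaker inhibitor, a lower number a stronger inhibitor), so far:
- compound 1, `O=c1c(Cl)c(CSC(=S)N2CCOCC2)oc2ccccc12`: compound 1 gives 11100 nM
- compound 2, `COc1ccc2occ(CSC(=S)N3CCCCC3)c(=O)c2c1`: compound 2 gives > 40000 nM, which is a limit of the assay and not a number
- compound 3, `O=c1c(CSC(=S)N2CCCCC2)coc2cc(Cl)ccc12`: compound 3 gives 380 nM

Of the two numbers recorded, compound 3 has the lowest, so it is the stronger inhibitor of cell growth among them. The nearest number belongs to compound 1, and it lies far higher, well beyond the usual scatter of repeated measurements. Compound 1 and compound 3 differ in more than one place, so their gap cannot be pinned on any single change. Compound 2 sits only at the limit of the assay the limit of > 40000 nM in this assay, at which 1 of the 3 values shown sits, and gives no number.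

Compound 4, `O=c1c(CSC(=S)N2CCOCC2)coc2cc(Cl)ccc12`, is compound 3 with one alteration: morpholin-4-yl in place of piperidin-1-yl on a thiocarbonyl carbon. Within the data shown here, no measured pair in this set differs by this change alone, so there is no measured step to lean on. The expectation is a modest rise in the number, in the direction of weaker inhibition, on the scale of a 3.9-fold higher number from compound 3 to compound 4 (0.60 log units; beyond the scatter). Compound 4 is therefore estimated at 1500 nM, with a plausible range from 300 nM to 8000 nM.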

Compound 4, half-maximal inhibitory concentration: 8100 nM
The estimate for compound 4 lay 5.4-fold (0.73 log units) below the measured number; measured number above the stated range.
By their numbers in this assay, from the lowest: compound 3; then compounds 4 and 1 (each within the scatter of the next). At a limit, above all of these: compound 2.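

In this assay, among these compounds, this is the first pair in the set that differs in one place only, and it gives the change a size: the step is a 21-fold higher number from compound 3 to compound 4 (1.33 log units; beyond the scatter) and counts as large. On a thiocarbonyl carbon whose other neighbour is sulfur, morpholin-4-yl is therefore no neutral stand-in for piperidin-1-yl in this pair, even though the two groups have the same number of heavy atoms and each is one six-membered non-aromatic ring. What separates them on paper is small, an oxygen in place of a carbon and a single hydrogen-bond acceptor, yet nothing recorded here bears on why the number rises so far, and the step alone cannot settle the cause.

Whether a step of this size repeats on the core of compound 1 remains an open question. Also open, as far as these compounds go, is how the core of compound 3 would respond on the same thiocarbonyl carbon to piperazin-1-yl, with a second ring nitrogen, or to an open-chain amine such as diethylamino.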